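The compounds below may be only part of what the source reports. "The series", "measured", "known", "first", "only" and "open" are said of these compounds alone.

Measured compounds:
compound 1 `COc1ccc(/C=N/c2ccc(OCc3ccccc3)cc2)c(O)c1`: 23600 nM
compound 2 `Oc1cccc(/C=N/c2ccc(OCc3ccccc3)cc2)c1O`: 6870 nM
compound 3 `Oc1ccc(Cl)cc1/C=N/c1ccc(OCc2ccccc2)cc1`: 24800 nM

Values are from an assay on isolated protein for inhibition of Amine oxidase [flavin-containing] B (Homo sapiens), read by fluorescence and Amplex Red, with stated times of 15 min and 20 min; a higher number here means a weaker inhibitor, a lower number a stronger inhibitor. Compound 3 gives the highest number of the three; compound 1 sits within the scatter of it, and compound 2 gives a clearly lower number, the step being a 3.6-fold higher number from compound 2 to compound 3 (0.56 log units; beyond the scatter). Compound 4 `Oc1ccc(/C=N/c2ccc(OCc3ccccc3)cc2)c(O)c1` is not yet measured. Its change from compound 3: 2,4-dihydroxyphenyl in place of 5-chloro-2-hydroxyphenyl on a carbon with a double bond to nitrogen. For the measured compounds named here, the only step that bears on it is the one from compound 2 to compound 3, which is modest and runs in the opposite direction; a second hydroxyl entering in place of chlorine is thus expected to lower the number somewhat, though compound 1 warns the effect may be small. Compound 4 is estimated at 12000 nM (range 4500 nM to 32000 nM), a step of a 2.1-fold lower number from compound 3 to compound 4 (0.32 log units; beyond the scatter).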

Compound 4, half-maximal inhibitory concentration: 6780 nM
For compound 4 the middle estimate is 1.8-fold (0.25 log units) above the measured one; measured number inside the range.
By their numbers in this assay, from the lowest: compounds 4 and 2 (each within the scatter of the next); then compounds 1 and 3 (each within the scatter of the next).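

Chlorine is not the only thing separating these rings: 2,4-dihydroxyphenyl in place of 5-chloro-2-hydroxyphenyl gives a clear gain (a 3.7-fold lower number from compound 3 to compound 4 (0.56 log units; beyond the scatter)), of about the same size as the earlier step from the 2,3-dihydroxyphenyl compound, read in reverse. Between 2,4-dihydroxyphenyl and 2,3-dihydroxyphenyl the printed step does not separate the two compounds (a 1.0-fold lower number from compound 2 to compound 4 (0.01 log units; within the scatter)). The free hydroxyl itself counts, since hydrogen in place of methyl on that oxygen also lowers the number (a 3.5-fold lower number from compound 1 to compound 4 (0.54 log units; beyond the scatter)).

On these data alone, whether an amine in place of either hydroxyl would keep these numbers stays open. Nothing available accounts for these steps.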